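Trimethoxyphenyl to Dimethoxyphenyl: One Methoxy Removed

The source may report more compounds than this note shows. Statements on the series, on what has been measured and on what is new or still open speak of the compounds shown alone.

Measured compounds:
compound 1 `COc1cc(-c2cc(/C=C/C(=O)c3ccc(N)cc3)[nH]n2)cc(OC)c1OC` — 107%
compound 2 `COc1ccc(-c2cc(/C=C/C(=O)c3ccc(OC)c(OC)c3)[nH]n2)cc1` — 104%

In a functional assay on DU-145 cells (Homo sapiens) for cytotoxicity, read by sulforhodamine B assay, with a stated time of 48 h, tested at 0.01 uM (on this read-out higher numbers stand for a weaker effect at the one concentration tested and lower numbers for a stronger effect), compound 1 gives 107%. Compound 2 gives 104% in this assay, and the two values lie within the usual scatter of each other, so compound 1 stands level with compound 2.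

Compound 3 `COc1ccc(-c2cc(/C=C/C(=O)c3ccc(N)cc3)[nH]n2)cc1OC` has not been measured. It differs from compound 1 by hydrogen in place of methoxy on an aromatic carbon. For the measured compounds named here, no measured pair shows this step. Since compound 1 shows no effect at this concentration, the step is expected to stay within the scatter, a number 2 percentage points lower from compound 1 to compound 3 (within the scatter). Compound 3 is therefore estimated at 105%, between 95% and 115%.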

Compound 3, a percentage reported as activity, at one concentration (the size of the read-out at that concentration, not a potency): 109%
Estimate against measurement, compound 3: 4 percentage points below; the measured number falls inside the stated range.
By their numbers in this assay, from the lowest: compounds 2, 1 and 3 (each within the scatter of the next).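

In this assay, for the compounds shown here, hydrogen in place of methoxy on this aromatic carbon, ortho to a methoxy group and meta to a large group, gives a number 2 percentage points higher from compound 1 to compound 3 (within the scatter), the first single-place step here. At this one concentration, removing this methoxy leaves the read-out where it stood, but compound 1 shows no effect to lose, so the step says little about the position. No evidence bears on the reason for this result. Whether an amine or a hydroxy group on this carbon would shift the number remains open, as does the behaviour of these compounds at higher concentrations.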